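Benzoyl replacement, compound 2 to compound 3

The source may hold more compounds than are shown below. What is called first, only, known or untested is meant among the compounds shown, and "the series" means these compounds.

- compound 1 `Cc1cc(C)cc(C(=O)N(CCC(=O)NCc2ccccc2)Cc2ccc(C(=O)NO)cc2)c1` gives 3870 nM
- compound 2 `O=C(CCN(Cc1ccc(C(=O)NO)cc1)C(=O)c1ccccc1)NCc1ccccc1` gives 6660 nM

Both values come from a functional assay on NB1 cells (Homo sapiens) for antiproliferative activity, with a stated time of 72 h; a lower number here means a stronger inhibitor, a higher number a weaker inhibitor. For the measured compounds named here, compound 2 stands within the scatter of compound 1, the only other number available. Compound 3 `COc1cc(OC)cc(C(=O)N(CCC(=O)NCc2ccccc2)Cc2ccc(C(=O)NO)cc2)c1` differs from compound 2 as follows: 3,5-dimethoxyphenyl in place of phenyl on a carbonyl carbon, in words 3,5-dimethoxyphenyl in place of phenyl on a carbonyl carbon. Going by the values given here, the one measured step at this place is a 1.7-fold higher number from compound 1 to compound 2 (0.24 log units; within the scatter), with phenyl in place of 3,5-dimethylphenyl. A similarly small step toward a lower number is therefore expected, probably none beyond the scatter. In this assay the estimate for compound 3 is 4300 nM, with an expected range from 2000 nM to 9000 nM. The expected change is a 1.5-fold lower number from compound 2 to compound 3 (0.19 log units; within the scatter).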

Compound 3, half-maximal inhibitory concentration: 13300 nM
Compound 3: middle estimate off by 3.1-fold (0.49 log units), on the low side; measured number above the stated range.
By their numbers in this assay, from the lowest: compounds 1, 2 and 3 (each within the scatter of the next, the first and the last beyond it).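

In this assay this position now shows a difference between two substituted rings: 3,5-dimethoxyphenyl in place of 3,5-dimethylphenyl on a carbonyl carbon gives a 3.4-fold higher number from compound 1 to compound 3 (0.54 log units; beyond the scatter) as a modest step. The change from phenyl gives a 2.0-fold higher number from compound 2 to compound 3 (0.30 log units; within the scatter) and stays within the scatter, so neither substituted ring separates clearly from phenyl. No supporting data explain the difference between the two substituted rings. Still open, on these data alone, is whether an amine or a carboxylic acid on this ring would separate from phenyl beyond the scatter.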